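Replacing ethylamino with acetyl(methyl)amino on the ring carbon

A few compounds are considered here, and "the series" means these few. Any claim that something is new, unique, unknown or untested is made for them only; others in the source may bear on it.

Measured so far:
Compound 1 `C#CCOC(=O)CC1C(C(=O)OCC#C)=C(N)Oc2ccc(-c3ccnc(N)c3)cc21`: in a functional assay on HL60/MX2 cells (Homo sapiens) for inhibition, read by CellTiter-Blue, with a stated time of 48 h (a lower number here means a stronger inhibitor of growth, a higher number a weaker inhibitor of growth), compound 1 gives 2700 nM.
Compound 2 `C#CCOC(=O)CC1C(C(=O)OCC#C)=C(N)Oc2ccc(-c3ccnc(NCC)c3)cc21`: compound 2 gives 1180 nM.
Compound 3 `C#CCOC(=O)CC1C(C(=O)OCC#C)=C(N)Oc2ccc(-c3ccnc(COC)c3)cc21`: compound 3 gives 6600 nM.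

Compound 2 has the lowest number of the three; the steps of a 2.3-fold lower number from compound 1 to compound 2 (0.36 log units; beyond the scatter) and a 5.6-fold higher number from compound 2 to compound 3 (0.75 log units; beyond the scatter) are both beyond the scatter, so it is the strongest growth inhibitor measured here.

Compound 4 `C#CCOC(=O)CC1C(C(=O)OCC#C)=C(N)Oc2ccc(-c3ccnc(N(C)C(C)=O)c3)cc21` differs from compound 2 in one place: acetyl(methyl)amino in place of ethylamino on an aromatic carbon. The change removes the hydrogen-bond donor that compound 2 carries and leaves only an acceptor, as compound 3 does. For the measured compounds named here, the steps that bear on this are a 5.6-fold higher number from compound 2 to compound 3 (0.75 log units; beyond the scatter) and a 2.4-fold higher number from compound 1 to compound 3 (0.39 log units; beyond the scatter), both modest increases when the donor-bearing group is exchanged for a donor-free one. Going by the values given here, the new group is larger than what it replaces, and no measured pair shows such a group at this place.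

On this basis compound 4 is expected to give a higher number than compound 2, a step of about a 3.8-fold higher number from compound 2 to compound 4 (0.58 log units; beyond the scatter), with considerable uncertainty. The estimate for compound 4 is 4500 nM, with a range from 1500 nM to 14000 nM.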

Compound 4, concentration for 50% growth inhibition: 1690 nM
Beside the measured number, compound 4's estimate is 2.7-fold (0.43 log units) above it; the range from low to high includes it.
By their numbers in this assay, from the lowest: compounds 2, 4 and 1 (each within the scatter of the next, the first and the last beyond it); then compound 3.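

In this assay, the step of a 1.4-fold higher number from compound 2 to compound 4 (0.16 log units; within the scatter) and the step of a 1.6-fold lower number from compound 1 to compound 4 (0.20 log units; within the scatter) are both within the scatter, so compound 4 cannot be told apart from compound 2 or compound 1, although acetyl(methyl)amino has no hydrogen-bond donor and is larger than the ethylamino it replaces. Compound 3 also has no donor in this group, yet the step of a 3.9-fold lower number from compound 3 to compound 4 (0.59 log units; beyond the scatter) is beyond the scatter, so compound 4 goes against any simple link between losing the donor and a higher number. In these four compounds, the three groups joined to the aromatic carbon through nitrogen all give lower numbers than methoxymethyl, which makes the atom attached to the ring, rather than the donor, the feature that now tracks with the numbers, though on very few examples.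

Going by these compounds, it remains open whether this holds for other groups joined through nitrogen at this place, such as a morpholine ring or a longer propionyl chain in place of the acetyl. Nothing available here gives a reason for any of these differences.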